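A few compounds are considered here, and "the series" means these few. Any claim that something is new, unique, unknown or untested is made for them only; others in the source may bear on it.

Two compounds of this series have a number in an ADME assay on the whole organism for metabolic stability, with Mus musculus as the target, at a dose of 50 mg/kg by the oral route; a higher number here means that the compound lasts longer, a lower number that the compound disappears faster. Compound 1 `O=C(NCc1ccc(N2CCC(c3ccc(OC(F)(F)F)cc3)CC2)cc1)c1cc([N+](=O)[O-])cc([N+](=O)[O-])c1` gives 5.52 h in this assay, and compound 2 `O=C(NCc1ccc(N2CCN(c3ccc(F)cc3)CC2)cc1)c1cc([N+](=O)[O-])cc([N+](=O)[O-])c1` gives 13.6 h. Of the two, compound 1 stands lowest, and its gap to compound 2 lies beyond the usual scatter. For the measured compounds named here, no pair of measured compounds differing in a single place is available, so no measured step can be quoted for any structural change.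

Compound 3 `O=C(NCc1ccc(N2CCC(C(F)(F)F)CC2)cc1)c1cc([N+](=O)[O-])cc([N+](=O)[O-])c1` is not yet measured. It differs from compound 1 in one place: trifluoromethyl in place of 4-(trifluoromethoxy)phenyl on a saturated ring carbon. The rest of compound 1 is unchanged. Going by the values given here, with no measured step on a comparable change, the size of the step in this assay has no anchor; the expectation is a small step, with no firm direction, so the working assumption is a half-life not far from that of compound 1, and nothing beyond the scatter. The estimate for compound 3 in this assay is 6.5 h, with a range of 3 h to 14 h. This corresponds to an expected step of a 1.2-fold higher number from compound 1 to compound 3 (0.07 log units; within the scatter).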

Compound 3, half-life: 3.63 h
Beside the measured number, compound 3's estimate is 1.8-fold (0.25 log units) above it; the range from low to high includes it.
By their numbers in this assay, from the lowest: compounds 3 and 1 (each within the scatter of the next); then compound 2.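

In this assay, for the compounds shown here, the trifluoromethyl for 4-(trifluoromethoxy)phenyl exchange on a saturated ring carbon gives the first single-place step, a 1.5-fold lower number from compound 1 to compound 3 (0.18 log units; within the scatter). At this place, three ring bonds from the ring nitrogen, the half-life therefore does not separate a group of 11 heavy atoms carrying a six-membered aromatic ring from a group of 4 heavy atoms with no ring, so the aromatic ring of the leaving group has no measurable bearing on this read-out in this one pair. Going by these compounds alone, nothing measured on these compounds speaks to the mechanism behind this result, and the single step supports no explanation of it.

Going by these compounds, whether this tolerance extends to other kinds of group at the same ring carbon remains open, for example a hydroxyl, a primary amine, a carboxylic acid or a longer alkyl chain. Compound 2 differs from compound 1 and from compound 3 in more than one place, so its number cannot be tied to any single change, and what distinguishes it in this assay also stays unresolved.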